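Iminosugar aryl series: mirror-image step to compound 4

The source may hold more compounds than are shown below. What is called first, only, known or untested is meant among the compounds shown, and "the series" means these compounds.

Compound 1 `O[C@@H]1[C@@H](O)CN[C@H]1c1ccc(-c2ccccc2)cc1`: 15.6%
Compound 2 `O[C@@H]1[C@@H](O)CN[C@H]1c1ccccc1`: 24.6%
Compound 3 `O[C@H]1[C@H](O)CN[C@@H]1CCCc1ccccc1`: 26.5%

In an assay on lysosomes for inhibition of Maltase-glucoamylase (Homo sapiens), read by spectrophotometry, tested at 1000 uM (a lower number here means less inhibition, a higher number more inhibition at the concentration tested (going by the name of the read-out)), compound 2 stands second highest of the three figures; compound 3 is nearest, within the scatter, and compound 1 is furthest, also within the scatter. Among the measured compounds shown here, the single one-place step measured, a number 9 percentage points higher from compound 1 to compound 2 (within the scatter), lies within the scatter. Compound 4 `O[C@H]1[C@H](O)CN[C@@H]1c1ccccc1` differs from compound 2 as follows: the two compounds have the same atoms and bonds and differ only in configuration as drawn: 3 of 3 stereo elements differ (all stereocentres are inverted: mirror images); a stereocentre at a saturated ring carbon is drawn S in compound 2 and R in compound 4; a stereocentre at a saturated ring carbon is drawn S in compound 2 and R in compound 4; a stereocentre at a saturated ring carbon is drawn S in compound 2 and R in compound 4. For the measured compounds named here, no measured step inverts configuration, so no step bears directly on this change; compound 3, drawn in the opposite configuration, sits within the scatter of compound 2. A step within the scatter is therefore expected, a number 0.6 percentage points lower from compound 2 to compound 4 (within the scatter). Compound 4 is estimated at 24%, between 8% and 42%.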

Compound 4, a percentage reported as inhibition, at one concentration (the size of the read-out at that concentration, not a potency): 29%
Estimate against measurement, compound 4: 5 percentage points below; low and high end bracket the measured number.
By their numbers in this assay, from the lowest: compounds 1, 2, 3 and 4 (each within the scatter of the next, the first and the last beyond it).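

In this assay, the new pair gives the series its first direct reading of configuration: a number 4.4 percentage points higher from compound 2 to compound 4 (within the scatter). Inverting all three stereocentres therefore does not separate these mirror images at the concentration tested. The comparison isolates configuration as the only change: the fact that compounds 2 and 4 differ only in the configuration as drawn

Open, as far as these compounds go, is whether inverting only one or two of the stereocentres would give a step beyond the scatter. Also open, from the compounds shown here alone, is whether the two configurations would separate with an amine or a carboxylic acid in place of hydrogen on the aromatic carbon.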